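Methyl for methoxy on the benzoyl ring of compound 1

A few compounds are considered here, and "the series" means these few. Any claim that something is new, unique, unknown or untested is made for them only; others in the source may bear on it.

Compound 1 `COC(=O)c1c(Nc2ccc(C)cc2)sc(C(=O)c2ccc(OC)cc2)c1C` is one of three analogues carrying the same core and differing in the substituent on the anilino ring. In a functional assay, with a stated time of 150 min, tested at 25 ug/mL (a higher number here means a stronger effect of the compound at the concentration tested, a lower number a weaker effect), compound 1 gives "not active" (no number reported), so no single number places it. Compound 2 `COC(=O)c1c(Nc2ccc(F)cc2)sc(C(=O)c2ccc(OC)cc2)c1C` gives 20.2% in this assay. Compound 3 `COC(=O)c1c(Nc2ccc(Cl)cc2)sc(C(=O)c2ccc(OC)cc2)c1C` gives "not active" (no number reported) in this assay. Compound 4 `COC(=O)c1c(Nc2ccc(C)cc2)sc(C(=O)c2ccc(C)cc2)c1C` has not yet been measured. Its change from compound 1 is methyl in place of methoxy on an aromatic carbon. For the measured compounds named here, with no measured step for this change and compound 1 without a number, any step is expected to be small, probably none beyond the scatter, and low activity is expected for compound 4. In this assay compound 4 is estimated at 8%, between 0% and 25%.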

Compound 4, a percentage reported as activity, at one concentration (the size of the read-out at that concentration, not a potency): "not active" (no number reported)
The entry for compound 4 holds no number; no gap can be computed for the estimate.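

Compound 1 and compound 4 both lack a number, so no step can be read between them. From the compounds shown here alone, whether methoxy to methyl alters activity on a measurable analogue such as compound 2 stays open. No evidence bears on this result.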